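Furan-2-yl to Thiophen-2-yl Across Two Related Cores

The compounds below may be only part of what the source reports. "The series", "measured", "known", "first", "only" and "open" are said of these compounds alone.

Measured so far:
compound 1 `c1ccc(C(/N=C2\CCCCN2)c2ccco2)cc1` — 13%
compound 2 `c1ccc(C(/N=C2\CCCCCN2)c2ccco2)cc1` — 5%
compound 3 `c1ccc(C(/N=C2\CCCCN2)c2cccs2)cc1` — 13%

Of the compounds shown here, three have been tested in a functional assay on the whole organism (plasma, strain Sprague-Dawley) with Rattus norvegicus as the target, with a stated time of 2 h, at a dose of 12.5 mg/kg by the oral route; on this read-out higher numbers stand for a stronger effect at the one dose given and lower numbers for a weaker effect. Compound 1 `c1ccc(C(/N=C2\CCCCN2)c2ccco2)cc1` gives 13% in this assay. Compound 3 `c1ccc(C(/N=C2\CCCCN2)c2cccs2)cc1` carries the change (thiophen-2-yl in place of furan-2-yl on a saturated chain carbon bound to an aromatic carbon and a double-bonded nitrogen), and in this assay compound 3 gives 13%; the step of no change at the digits printed from compound 1 to compound 3 (within the scatter) shows this change leaving the read-out where it was. Compound 2 `c1ccc(C(/N=C2\CCCCCN2)c2ccco2)cc1` rests on a different core; how its core differs from that of compound 1 is not broken down here. In this assay compound 2 gives 5%, a number within the scatter of compound 1 and of compound 3, so no order among the three can be claimed.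

Compound 4 `c1ccc(C(/N=C2\CCCCCN2)c2cccs2)cc1` has not been measured. It stands to compound 2 as compound 3 stands to compound 1: the change is thiophen-2-yl in place of furan-2-yl on a saturated chain carbon bound to an aromatic carbon and a double-bonded nitrogen, the same kind of change with the same place wording. Because no change at the digits printed from compound 1 to compound 3 (within the scatter) was flat, the step from compound 2 to compound 4 is expected to be about a number 1 percentage points higher from compound 2 to compound 4 (within the scatter). In this assay compound 4 is therefore estimated at 6%, expected to fall between 0% and 16%, resting on the value of compound 2 5% and on the flat step already seen.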

Compound 4, a percentage reported as inhibition, in the whole organism at one dose (the size of the read-out at that dose, not a potency): 23%
For compound 4 the middle estimate is 17 percentage points below the measured one, and the stated range ends below it.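

In this assay, thiophen-2-yl in place of furan-2-yl on a saturated chain carbon bound to an aromatic carbon and a double-bonded nitrogen gives a number 18 percentage points higher from compound 2 to compound 4 (beyond the scatter), so the flat result on the core of compound 1 does not carry over to the core of compound 2. In this series, the outcome of the same change therefore depends on the core that carries it, and the two steps differ by more than their scatter: the same change on two cores in this assay, no change at the digits printed (within the scatter) from compound 1 to compound 3 and a number 18 percentage points higher (beyond the scatter) from compound 2 to compound 4, 18 percentage points apart, beyond the scatter of two such steps What this does not show is why the two cores part ways, or whether the difference would hold at another dose or time, since it rests on a single pair of compounds for each core and on a read-out of effect size at one dose rather than a potency.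

The compounds shown hold only furan-2-yl and thiophen-2-yl at this place, on only two cores, so it remains open whether the rise seen for compound 4 extends to any further core. Also open, going by these compounds, is how an amine or a carboxylic acid in place of thiophen-2-yl on that same carbon would read on either core.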